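Adding a Methyl Beside the Chlorine on the Phenyl Ring

The source may hold more compounds than are shown below. What is called first, only, known or untested is meant among the compounds shown, and "the series" means these compounds.

Compound 1 `Cc1nc2ccccc2n1CCCCOc1ccccc1`: > 50 uM
Compound 2 `CCc1nc2ccccc2n1CCCCOc1cccc(Cl)c1`: 22 uM
Compound 3 `CCc1nc2ccccc2n1CCCCOc1ccccc1Cl`: 16 uM

These three compounds share one core and differ only in the phenyl ring at the far end of the chain. They were tested in an ADME assay on Vero cells (Chlorocebus sabaeus) for cytotoxicity, read by luminescence, with a stated time of 2 days; on this read-out higher numbers stand for lower toxicity in this test and lower numbers for higher toxicity in this test. For compound 1 the result is a limit of the test rather than a number (the limit of > 50 uM in this assay, at which 1 of the 3 values shown sits). Among the two numbers that were measured, compound 2 gives the higher one, and its nearest neighbour is compound 3; the step of a 1.4-fold lower number from compound 2 to compound 3 (0.14 log units; within the scatter) is the only measured step between compounds that differ in one place.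

Compound 4 `CCc1nc2ccccc2n1CCCCOc1ccc(C)c(Cl)c1` is not yet measured. Relative to compound 2 the change is methyl in place of hydrogen on an aromatic carbon. Going by the values given here, none of the measured steps adds a group; the one step that exists moves the chloro group around the ring, and that step stays within the scatter. Among the compounds with values here, no measured step therefore speaks for a change beyond the scatter here. The expected step of a 1.1-fold lower number from compound 2 to compound 4 (0.04 log units; within the scatter) is accordingly a small one, with no clear direction. Compound 4 is estimated to give 20 uM in this assay, with a range from 8 uM to 50 uM.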

Compound 4, half-maximal toxic concentration: 14 uM
For compound 4 the middle estimate is 1.4-fold (0.15 log units) above the measured one; the measured number falls inside the stated range.
By their numbers in this assay, from the lowest: compounds 4, 3 and 2 (each within the scatter of the next). At a limit, above all of these: compound 1.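

Going by these compounds alone, this is the first step that adds a group instead of moving one. In this assay, a methyl on the aromatic carbon ortho to a chloro group and para to a large group gives a 1.6-fold lower number from compound 2 to compound 4 (0.20 log units; within the scatter), so at this position the added methyl produces no difference that can be told apart from the ordinary spread of repeated measurements. The other comparison reads the same way, with a 1.1-fold lower number from compound 3 to compound 4 (0.06 log units; within the scatter), so 3-chloro-4-methylphenyl and 2-chlorophenyl cannot be separated in this test, and nothing in the data gives a reason for any of these numbers.

From the compounds shown here alone, a single methyl says little about what this position tolerates, so it stays open whether a methoxy group, an amine or a carboxylic acid in its place would also stay within the scatter of compound 2. Going by these compounds, it also stays open whether a methyl at this position would read the same on a phenyl ring without the chloro group, or on a compound with a longer chain between the shared core and the ring.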